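A few compounds are considered here, and "the series" means these few. Any claim that something is new, unique, unknown or untested is made for them only; others in the source may bear on it.

Compound 1, `Oc1ccc(-c2cc(-c3ccsc3)cc(-c3ccccc3O)n2)cc1`: in a functional assay on DU-145 cells (Homo sapiens) for cytotoxicity, read by CCK-8 assay (a lower number here means a stronger inhibitor, a higher number a weaker inhibitor), compound 1 gives > 50000 nM, which is a limit of the assay.
Compound 2, `Oc1ccc(-c2cc(-c3ccoc3)cc(-c3ccccc3O)n2)cc1`: in this assay compound 2 gives 28000 nM.
Compound 3, `Oc1ccccc1-c1cc(-c2ccccn2)cc(-c2ccccc2O)n1`: in this assay compound 3 gives > 50000 nM, again a limit of the assay.

Compound 3 thus stands at the limit, and only a limit is known for it; no number places it against the others. Two of the three values shown sit there, as the limit of > 50000 nM in this assay, at which 2 of the 3 values shown sit, shows. The step to compound 4, `Oc1ccc(-c2cc(-c3ccccn3)cc(-c3ccccc3O)n2)cc1`, keeps all atoms and joins them differently: 4-hydroxyphenyl in place of 2-hydroxyphenyl on an aromatic carbon. After the change the core carries a 4-hydroxyphenyl group, as in compounds 1 and 2, with a pyridin-2-yl group in place of their thiophen-3-yl or furan-3-yl.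

For the measured compounds named here, the only measured step, an at least 1.7-fold lower number from compound 1 to compound 2 (0.25 log units; that floor lies within the scatter), swaps one five-membered ring for another and does not touch a hydroxyphenyl group, so nothing measured bears directly on this change. Compounds 1 and 2 show that the 4-hydroxyphenyl arrangement reaches at best a weak number in this assay. Compound 4 is therefore expected to stay near the limit, a step of a number no higher from compound 3 to compound 4 (the limit leaves the size open), with an estimated value of 50000 nM, ranging from 20000 nM to 150000 nM.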

Compound 4, half-maximal inhibitory concentration: 25400 nM
Beside the measured number, compound 4's estimate is 2.0-fold (0.29 log units) above it, and the stated range covers the measured number.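

In this assay, as far as these compounds go, 4-hydroxyphenyl in place of 2-hydroxyphenyl gives an at least 1.9-fold lower number from compound 3 to compound 4 (0.29 log units; that floor lies within the scatter), so this change brings a pyridin-2-yl compound off the limit, although the true size of the step stays unknown. With 4-hydroxyphenyl kept in place, pyridin-2-yl in place of furan-3-yl gives a 1.1-fold lower number from compound 2 to compound 4 (0.04 log units; within the scatter), so a six-membered ring at this position cannot be told apart from that five-membered ring, while pyridin-2-yl in place of thiophen-3-yl gives an at least 1.9-fold lower number from compound 1 to compound 4 (0.29 log units; that floor lies within the scatter). The 4-hydroxyphenyl group alone does not guarantee a measured number, since compound 1 carries it and still stays at a limit.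

The compounds shown leave open whether the hydroxyl group is needed at all, and what a methoxy group, an amine or a carboxylic acid would do in its place on that phenyl ring. The true size of every step that starts from a limit also stays open, and some of the values give no number to compare: the limit of > 50000 nM in this assay, at which 2 of the 4 values shown sit.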